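The compounds below may be only part of what the source reports. "The series", "measured", "known", "first", "only" and "open" are said of these compounds alone.

Measured so far:
compound 1 `N#C/C(=C\c1ccc(Cl)cc1)C(=O)c1ccc[nH]1`: 34000 nM
compound 2 `COc1ccc(CNC(=O)/C(C#N)=C/c2ccc[nH]2)cc1`: 47000 nM

Both were tested in a functional assay on BE(2)-C cells (Homo sapiens) for inhibition, read by MTT assay, with a stated time of 72 h; on this read-out higher numbers stand for weaker inhibition of growth and lower numbers for stronger inhibition of growth. In this assay compound 1 gives 34000 nM and compound 2 gives 47000 nM; the gap between them lies within the usual scatter, so neither can be set apart from the other. Compound 3 `COc1ccc(CNC(=O)/C(C#N)=C/c2ccc(C)cc2)cc1` is not yet measured. It differs from compound 2 in one place: 4-methylphenyl in place of 1H-pyrrol-2-yl on a double-bonded chain carbon bound to a double-bonded chain carbon. Among the compounds with values here, no measured pair shows such a change, so nothing here points to a direction, and only a step within the scatter is expected, which the estimate states as a 1.2-fold lower number from compound 2 to compound 3 (0.07 log units; within the scatter). Compound 3 is expected at 40000 nM, with a range from 12000 nM to 130000 nM.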

Compound 3, concentration for 50% growth inhibition: 35000 nM
For compound 3 the middle estimate is 1.1-fold (0.06 log units) above the measured one; measured number inside the range.
By their numbers in this assay, from the lowest: compounds 1, 3 and 2 (each within the scatter of the next).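

Going from 1H-pyrrol-2-yl to 4-methylphenyl on a double-bonded chain carbon bound to a double-bonded chain carbon gives, in this assay, a 1.3-fold lower number from compound 2 to compound 3 (0.13 log units; within the scatter), so the two rings cannot be told apart at this position. The change also removes the hydrogen-bond donor of the 1H-pyrrol-2-yl group, with no step beyond the scatter. Nothing measured here offers a reason for this result.

Still open, from the compounds shown here alone, is whether any group at this position can move the number beyond the scatter. A longer chain, or a phenyl ring carrying an amine or a carboxylic acid, would test this.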